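This account rests on a few compounds, and the source may have more. Where it says the series, first, only, none or still open, it means among the compounds named here.

Series notes. The shared core carries a methyl-bearing amine nitrogen joined through a triazene to a benzoic acid; the chain on that nitrogen is varied. Compound 3 `CCCCN(C)/N=N/c1ccc(C(=O)O)cc1` gives 15500000 nM in a physicochemical assay for solubility, in phosphate buffer, at pH 7.4; a higher number here means a more soluble compound, a lower number a less soluble compound. Compound 1 `CCCCCN(C)/N=N/c1ccc(C(=O)O)cc1` gives 4280000 nM, and compound 2 `CCCCCCCN(C)/N=N/c1ccc(C(=O)O)cc1` gives 410000 nM. Compound 3 is the highest of the three, with a 3.6-fold higher number from compound 1 to compound 3 (0.56 log units; beyond the scatter) and a 38-fold higher number from compound 2 to compound 3 (1.58 log units; beyond the scatter). The change ethyl in place of hydrogen on a saturated chain carbon, five bonds along the chain from an amine nitrogen gives a 10-fold lower number from compound 1 to compound 2 (1.02 log units; beyond the scatter). Compound 4 `CCCCCCN(C)/N=N/c1ccc(C(=O)O)cc1` is unmeasured; it differs from compound 3 by ethyl in place of hydrogen on a saturated chain carbon, four bonds along the chain from an amine nitrogen. For the measured compounds named here, this is the same kind of change as the one from compound 1 to compound 2, not the same: the place line reads four bonds along the chain from an amine nitrogen for compound 3 to compound 4 and five bonds for compound 1 to compound 2. The cores differ by hydrogen in place of methyl on a saturated chain carbon, four bonds along the chain from an amine nitrogen. In this assay, compound 4 is expected to show an 11-fold lower number from compound 3 to compound 4 (1.04 log units; beyond the scatter), close to the step already seen, because a 10-fold lower number from compound 1 to compound 2 (1.02 log units; beyond the scatter) for the same kind of change. Compound 4 is estimated at 1400000 nM, between 600000 nM and 3500000 nM.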

Compound 4, solubility: 2980000 nM
Estimate against measurement, compound 4: 2.1-fold (0.33 log units) below, within the range that was stated.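

In this assay, ethyl in place of hydrogen gives a 5.2-fold lower number from compound 3 to compound 4 (0.72 log units; beyond the scatter) at four bonds along the chain from an amine nitrogen, and the related change on the other core gives a 10-fold lower number from compound 1 to compound 2 (1.02 log units; beyond the scatter) at five bonds, so the direction carries from one core to the other while the printed size is smaller here. Among the other steps, the series shows a 7.3-fold higher number from compound 2 to compound 4 (0.86 log units; beyond the scatter) and also a 1.4-fold lower number from compound 1 to compound 4 (0.16 log units; within the scatter), the last lying within the scatter, so compound 1 and compound 4 are not told apart in this assay. This single pair of cores shows agreement in direction only; it does not show that the size of the step transfers to other cores, and nothing measured here accounts for the difference between the two steps.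

The compounds shown leave open whether the same change behaves alike on a longer chain or on a chain ending in a hydroxyl group. Also open, on these data alone, is how the step would run with an amide in place of the carboxylic acid.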